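A few compounds are considered here, and "the series" means these few. Any claim that something is new, unique, unknown or untested is made for them only; others in the source may bear on it.

Measured so far, with their readings in an ADME assay on MT4 cells (Homo sapiens) for cytotoxicity, read by MTT assay; on this read-out higher numbers stand for lower toxicity in this test and lower numbers for higher toxicity in this test:
compound 1, `Cc1ccc(NC(=S)OCCc2ccccn2)cc1`: 75000 nM
compound 2, `FC(F)(F)c1ccc(NC(=S)OCCc2ccccn2)cc1`: 50000 nM
compound 3, `CC(=O)c1ccc(NC(=S)OCCc2ccccn2)cc1`: >= 100000 nM

All three share one core and differ only in the substituent on the aromatic ring. Compound 1 and compound 2 both give real numbers, while compound 3 is reported only as a limit of this assay. Compound 3 stands at the limit of >= 100000 nM in this assay, at which 1 of the 3 values shown sits, so its place on the scale is a floor rather than a point. The two steps into it were small: an at least 1.3-fold higher number from compound 1 to compound 3 (0.12 log units; that floor lies within the scatter) and an at least 2.0-fold higher number from compound 2 to compound 3 (0.30 log units; that floor lies within the scatter), and the pair compound 1 to compound 2 showed a 1.5-fold lower number from compound 1 to compound 2 (0.18 log units; within the scatter).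

Compound 4, `S=C(Nc1ccc(Br)cc1)OCCc1ccccn1`, is the next change: bromo in place of acetyl on an aromatic carbon. Every substituent swap among the measured compounds stayed within the scatter, so the move to bromo is expected to stay there too, with no step beyond the scatter in this assay. Compound 4 is therefore estimated at 70000 nM, between 35000 nM and 140000 nM. The expected step is an at least 1.4-fold lower number from compound 3 to compound 4 (0.15 log units; that floor lies within the scatter).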

Compound 4, half-maximal cytotoxic concentration: 37000 nM
Compound 4: the middle estimate sits 1.9-fold (0.28 log units) above what was measured; the measured number falls inside the stated range.
By their numbers in this assay, from the lowest: compounds 4, 2 and 1 (each within the scatter of the next, the first and the last beyond it). At a limit, above all of these: compound 3.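

In this assay, the substituent para to a large group now produces steps beyond the scatter, which no earlier swap at this place did, with bromo in place of methyl (a 2.0-fold lower number from compound 1 to compound 4 (0.31 log units; beyond the scatter)) and bromo in place of acetyl (an at least 2.7-fold lower number from compound 3 to compound 4 (0.43 log units; beyond the scatter)). Bromo in place of trifluoromethyl, however, stays within the scatter (a 1.4-fold lower number from compound 2 to compound 4 (0.13 log units; within the scatter)), so these two groups cannot be told apart here, and the range across this position is wider than the first three compounds showed. The true size of the step from acetyl stays unknown, since compound 3 is reported only as a limit: the limit of >= 100000 nM in this assay, at which 1 of the 4 values shown sits.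

The compounds shown leave open how far the number could fall at this place, and whether the low end belongs to halogens generally, as chloro or iodo might show. They also leave open where an amine or a carboxylic acid at this position would fall on the scale.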